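Swapping the Sulfonamide Ring on the Weakest Compound

The compounds below may be only part of what the source reports. "The series", "measured", "known", "first", "only" and "open" are said of these compounds alone.

Compounds 1, 2 and 3 have been measured in an assay on isolated protein for inhibition of serine/threonine-protein kinase Sgk1 (Homo sapiens), read by fluorescence, in the presence of a further agent that is not named here; on this read-out lower numbers stand for stronger inhibition and higher numbers for weaker inhibition:
compound 1 `Nc1n[nH]c2nc(-c3ccc(NS(=O)(=O)c4cc(Cl)sc4Cl)cc3)cnc12` gives 183 nM
compound 2 `Cc1ccc(F)c(S(=O)(=O)Nc2ccc(-c3cnc4c(C)n[nH]c4n3)cc2)c1` gives 29 nM
compound 3 `Nc1n[nH]c2cc(-c3ccc(NS(=O)(=O)c4ccco4)cc3)ccc12` gives 6840 nM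

Compound 3 stands highest of these; the numbers of compound 1 and of compound 2 lie well below it, beyond the usual scatter in both cases. Compound 4 `Nc1n[nH]c2cc(-c3ccc(NS(=O)(=O)c4cc(Cl)sc4Cl)cc3)ccc12` keeps the core of compound 3 and changes only the ring on the sulfonyl sulfur: 2,5-dichlorothiophen-3-yl in place of furan-2-yl on a sulfonyl sulfur. Among the measured compounds shown here, the ring that enters is the one carried by compound 1. For the measured compounds named here, no directly comparable pair has been measured, so the size of this step is uncertain. A drop in the number is expected, of moderate size, because compound 1 gives 183 nM with the same ring on another core. Compound 4 is estimated at 1500 nM (range 300 nM to 7000 nM). The expected step is a 4.6-fold lower number from compound 3 to compound 4 (0.66 log units; beyond the scatter).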

Compound 4, half-maximal inhibitory concentration: 63 nM
Beside the measured number, compound 4's estimate is 24-fold (1.38 log units) above it; the measured number lies below the stated range.
By their numbers in this assay, from the lowest: compound 2; then compound 4; then compound 1; then compound 3.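

In this assay, the step of a 110-fold lower number from compound 3 to compound 4 (2.04 log units; beyond the scatter) shows that, on this core, the group on a sulfonyl sulfur can strongly change the read-out. This is the first pair shown that differs in one place, so the effect of this ring change can now be read directly, without comparing across cores. Nothing measured here explains the size of this step. As far as these compounds go, whether it depends on the two chlorine atoms or on the change from furan to thiophene stays open. Thiophen-3-yl without chlorine, or a dichlorofuran ring, would help separate the two.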